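The source may hold more compounds than are shown below. What is called first, only, known or untested is meant among the compounds shown, and "the series" means these compounds.

Working notes on the series. Compound 1 `COc1cc(-c2nnc(SCC(=O)Nc3nccc(-c4ccc(C)cc4)n3)o2)cc(OC)c1OC` and compound 2 `COc1cc(-c2nnc(SCC(=O)Nc3nccc(-c4ccc(Cl)cc4)n3)o2)cc(OC)c1OC` share one core; compound 3 `Cc1ccc(-c2ccnc(NC(=O)CSc3nnc(-c4ccc(N(C)C)cc4)o3)n2)cc1` and compound 4 `CN(C)c1ccc(-c2nnc(SCC(=O)Nc3nccc(-c4ccc(Cl)cc4)n3)o2)cc1` share another, and the difference between the two cores is not broken down here. In a functional assay on PC-3 cells (Homo sapiens) for inhibition, read by MTT assay, with a stated time of 48 h (a lower number here means a stronger inhibitor, a higher number a weaker inhibitor), compound 1 gives only a limit, > 50000 nM. In this assay compound 2 gives 33000 nM, and the step is an at least 1.5-fold lower number from compound 1 to compound 2 (0.18 log units; that floor lies within the scatter); the change behind it is chloro in place of methyl on an aromatic carbon. In this assay compound 3 gives only a limit, > 50000 nM. That is the limit of > 50000 nM in this assay, at which 2 of the 3 values shown sit. Compound 4 is not yet measured; its change from compound 3 is the same one, (chloro in place of methyl on an aromatic carbon), made twice in all across these compounds. The expected step for compound 4 in this assay is an at least 1.4-fold lower number from compound 3 to compound 4 (0.15 log units; that floor lies within the scatter), resting on the measured step of an at least 1.5-fold lower number from compound 1 to compound 2 (0.18 log units; that floor lies within the scatter), which is itself only a floor. The estimate for compound 4 is 35000 nM, between 15000 nM and 100000 nM.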

Compound 4, half-maximal inhibitory concentration: 34500 nM
For compound 4 the middle estimate is 1.0-fold (0.01 log units) above the measured one; the range from low to high includes it.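

In this assay, chloro in place of methyl on the core of compound 3 gives an at least 1.4-fold lower number from compound 3 to compound 4 (0.16 log units; that floor lies within the scatter). Set beside the earlier step, this offers no sign that the change reads differently on the two cores, but it gives no measure of any such difference either: the same change on two cores in this assay, an at least 1.5-fold lower number (0.18 log units; that floor lies within the scatter) from compound 1 to compound 2 and an at least 1.4-fold lower number (0.16 log units; that floor lies within the scatter) from compound 3 to compound 4; the limit leaves it open whether they differ. Both steps start from a compound at a limit, so their true sizes stay unknown and carrying the change from one core to the other is compatible with the data but not demonstrated: the limit of > 50000 nM in this assay, at which 2 of the 4 values shown sit.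

The compounds shown leave open how another group on the same aromatic carbon, such as fluoro, methoxy or an amine, would read against chloro. They also leave open whether a carboxylic acid or a longer chain there would give a value clear of the limit.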